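The compounds below may be only part of what the source reports. "The series", "measured", "known", "first", "only" and "open" are said of these compounds alone.

Measured compounds:
- compound 1, `Cc1ccccc1NC(=O)Nc1ccc(-n2cc(CCCN(C)C)nn2)cc1`, which in an assay on isolated protein for inhibition of ATP-dependent RNA helicase DDX3X (Homo sapiens), read by FRET, with stated times of 30 s and 40 min (a higher number here means a weaker inhibitor, a lower number a stronger inhibitor), gives 2900 nM
- compound 2, `Cc1ccccc1NC(=O)Nc1ccc(-n2cc(CCO)nn2)cc1`, which in this assay gives 13000 nM
- compound 3, `CCOC(=O)CCc1cn(-c2ccc(NC(=O)Nc3ccccc3C(F)(F)F)cc2)nn1`, which in this assay gives 2020 nM

Compound 3 has the lowest number of the three; compound 1 sits within the scatter of it, while compound 2 lies clearly higher. Compound 4, `CC(C)CC(=O)OCCc1cn(-c2ccc(NC(=O)Nc3ccccc3C(F)(F)F)cc2)nn1`, differs from compound 3 in one place: (isobutylcarbonyl)oxy in place of ethoxycarbonyl on a saturated chain carbon, two bonds along the chain from an aromatic carbon. Within the data shown here, the only measured step touching this position is the one from compound 1 to compound 2, where a hydroxy replaced a (dimethylamino)methyl group and the number moved by a 4.5-fold higher number from compound 1 to compound 2 (0.65 log units; beyond the scatter). That step swaps quite different groups from the present one, so it tells mainly that this end of the chain tolerates alteration with a modest shift at most. Compound 4 is therefore expected to stay close to compound 3, with an estimated step of a 1.2-fold higher number from compound 3 to compound 4 (0.09 log units; within the scatter) in this assay, neither clearly weaker nor clearly stronger. The estimate for compound 4 is 2500 nM, within a range from 800 nM to 8000 nM.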

Compound 4, half-maximal inhibitory concentration: 400 nM
Beside the measured number, compound 4's estimate is 6.3-fold (0.80 log units) above it, outside the stated range (below it).
By their numbers in this assay, from the lowest: compound 4; then compounds 3 and 1 (each within the scatter of the next); then compound 2.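

At this place on the chain, the step in this assay shows that the number can fall clearly as well as rise: (isobutylcarbonyl)oxy in place of ethoxycarbonyl gives a 5.1-fold lower number from compound 3 to compound 4 (0.70 log units; beyond the scatter). The earlier step at this end of the chain, from a different pair of groups, had only shown a rise, so this end of the chain is not merely tolerant of change. The two groups match in their counts of hydrogen-bond donors and acceptors and differ in heavy atoms, but nothing measured here explains the gain.

The compounds shown leave open whether the gain follows the larger isobutyl part or the reversed way the ester is joined, which an (ethylcarbonyl)oxy group could separate. They also leave open how a carboxylic acid, an amide or a longer chain would fare at this place.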